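A few compounds are considered here, and "the series" means these few. Any claim that something is new, unique, unknown or untested is made for them only; others in the source may bear on it.

Series notes, amine substituent on the shared core. Compound 1 `CC(C)(C)OC(=O)CCCN1CCc2c(sc(NC(=O)Nc3ccc(Cl)cc3)c2C(N)=O)C1` gives 560 nM in a functional assay (strain AB) with Danio rerio as the target, read by microscopy, with a stated time of 1 h; a higher number here means that more compound is needed for the effect, a lower number that less compound is needed. Compound 2 `COCCCN1CCc2c(sc(NC(=O)Nc3ccc(Cl)cc3)c2C(N)=O)C1` gives 2400 nM, and compound 3 `NC(=O)c1c(NC(=O)Nc2ccc(Cl)cc2)sc2c1CCN(CC1CCCC1)C2` gives 1830 nM. Compound 3 thus stands second highest of the three numbers: its nearest neighbour is compound 2, with a 1.3-fold lower number from compound 2 to compound 3 (0.12 log units; within the scatter), and its furthest is compound 1, with a 3.3-fold higher number from compound 1 to compound 3 (0.51 log units; beyond the scatter). Compound 4 `CCCN1CCc2c(sc(NC(=O)Nc3ccc(Cl)cc3)c2C(N)=O)C1` is not yet measured; it differs from compound 3 as follows: ethyl in place of cyclopentyl on a saturated chain carbon bound to an amine nitrogen in a ring. Going by the values given here, no measured step swaps cyclopentyl for ethyl. The nearest guide is the exchange of the amine substituent between compound 2 and compound 3, a 1.3-fold lower number from compound 2 to compound 3 (0.12 log units; within the scatter), which lies within the scatter, so a change confined to this part of the chain has so far moved the number little. The larger step of a 4.3-fold higher number from compound 1 to compound 2 (0.63 log units; beyond the scatter) is tied to the tert-butoxycarbonyl group, which is absent from compound 3 and compound 4 alike. Compound 4 is therefore expected to sit close to compound 3, with a 1.2-fold higher number from compound 3 to compound 4 (0.08 log units; within the scatter) not beyond the scatter. The estimate for compound 4 in this assay is 2200 nM, with a range from 1000 nM to 5000 nM.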

Compound 4, half-maximal effective concentration: 3500 nM
Beside the measured number, compound 4's estimate is 1.6-fold (0.20 log units) below it, within the range that was stated.
By their numbers in this assay, from the lowest: compound 1; then compounds 3, 2 and 4 (each within the scatter of the next).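

In this assay, removing the ring at this place gives no step beyond the scatter (a 1.9-fold higher number from compound 3 to compound 4 (0.28 log units; within the scatter)), so the cyclopentyl ring is not shown to matter here. Removing the methoxy from the chain likewise stays within the scatter (a 1.5-fold higher number from compound 2 to compound 4 (0.16 log units; within the scatter)), so compound 2, compound 3 and compound 4 cannot be told apart. Only the tert-butoxycarbonyl group stands clear of the rest, and the direct exchange for hydrogen gives the largest step in the set (a 6.3-fold higher number from compound 1 to compound 4 (0.80 log units; beyond the scatter)), which sets this group apart from a plain propyl chain on the same nitrogen.

The compounds shown leave open whether the carbonyl or the tert-butyl part carries this difference. A carboxylic acid or a methyl ester at the end of the chain would separate the two.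

Nothing at hand accounts for these steps.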